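A Trimethoxyphenyl Series Tested Against Breast Cancer Cells

The source may report more compounds than this note shows. Statements on the series, on what has been measured and on what is new or still open speak of the compounds shown alone.

Two compounds have so far been run in a functional assay on MCF7 cells (Homo sapiens) for inhibition, read by CCK-8 assay, with a stated time of 48 h; a lower number here means a stronger inhibitor, a higher number a weaker inhibitor. Compound 1, `COc1cc(-c2cc3nccc(-c4c[nH]c5ccccc45)n3n2)cc(OC)c1OC`, carries an indole on its shared core. Compound 2, `COc1cc(-c2ccnc3cc(-c4cccc(C#N)c4)nn23)cc(OC)c1OC`, carries a 3-cyanophenyl on a related core. In this assay compound 1 gives only a limit, > 10000 nM. In this assay compound 2 likewise gives only a limit, > 10000 nM. Among the measured compounds shown here, neither result is a number, so compound 2 stands on (the limit of > 10000 nM in this assay, at which 2 of the 2 values shown sit), with no measured step to compare against.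

Compound 3, `COc1cc(-c2ccnc3cc(-c4ccc5ccn(C)c5c4)nn23)cc(OC)c1OC`, is the next compound. For the measured compounds named here, its one difference from compound 2 is 1-methyl-1H-indol-6-yl in place of 3-cyanophenyl on an aromatic carbon. Going by the values given here, the change swaps one ring for a pair of fused rings, but the compounds measured so far give no step of this kind to learn from, and both sit at the limit.

The expected outcome is therefore no clear movement: the step of a number no higher from compound 2 to compound 3 (the limit leaves the size open) is estimated to stay within the usual scatter. Compound 3 is expected to give about 10000 nM, with a likely range from 2000 nM to 40000 nM.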

Compound 3, half-maximal inhibitory concentration: 74 nM
Compound 3: the middle estimate sits 140-fold (2.13 log units) above what was measured, and the stated range ends above it.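

In this assay, this position, an aromatic carbon of a five-membered aromatic ring with 2 nitrogen, proves sensitive to the group it carries: 1-methyl-1H-indol-6-yl in place of 3-cyanophenyl gives an at least 130-fold lower number from compound 2 to compound 3 (2.13 log units; beyond the scatter). The value for compound 2 is a limit and not a number, so this step gives only a minimum size, but even that minimum lies well beyond the usual scatter. Among the compounds shown here, the earlier compounds showed no measurable activity at all, whereas compound 3 gives the series its only actual number and so a first point for later changes to be compared with: the limit of > 10000 nM in this assay, at which 2 of the 3 values shown sit.

A single step cannot show which feature of the new group matters, whether the pair of fused rings, the methyl on the ring nitrogen or the point at which the indole is attached. It also leaves open how this position would respond to an indole with a hydrogen in place of that methyl, to an unsubstituted phenyl, or to a group of a different kind, such as an amine or a carboxylic acid.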